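A few compounds are considered here, and "the series" means these few. Any claim that something is new, unique, unknown or untested is made for them only; others in the source may bear on it.

Three compounds sharing one core have been followed in an in vitro ADME assay on microsomes from liver (Homo sapiens) for metabolic stability, tested at 5 uM (a lower number here means that the compound disappears faster, a higher number that the compound lasts longer), and they differ only in the group on one aromatic carbon. Compound 1 `CC(C)CCn1nc(-c2ccn(C)c2)c(O)c(C2=NS(=O)(=O)c3cc(NS(C)(=O)=O)ccc3N2)c1=O` gives 0.633 h, compound 2 `CC(C)CCn1nc(CC2=CCCC2)c(O)c(C2=NS(=O)(=O)c3cc(NS(C)(=O)=O)ccc3N2)c1=O` gives 0.15 h, and compound 3 `CCC(C)(C)c1nn(CCC(C)C)c(=O)c(C2=NS(=O)(=O)c3cc(NS(C)(=O)=O)ccc3N2)c1O` gives 0.1 h. Compound 3 therefore sits with compound 2 at the low end of these numbers. The data show a 1.5-fold lower number from compound 2 to compound 3 (0.18 log units; within the scatter), but also a 6.3-fold lower number from compound 1 to compound 3 (0.80 log units; beyond the scatter), which matches in kind a 4.2-fold lower number from compound 1 to compound 2 (0.63 log units; beyond the scatter).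

Compound 4 `CC(C)CCc1nn(CCC(C)C)c(=O)c(C2=NS(=O)(=O)c3cc(NS(C)(=O)=O)ccc3N2)c1O` has not yet been measured. It holds the same atoms as compound 3, joined differently: isopentyl in place of 1,1-dimethylpropyl on an aromatic carbon. The isopentyl group stays on the same aromatic carbon, next to the ring nitrogen. Within the data shown here, no measured step makes this exact exchange. The closest guide is the exchange between the two groups without the 1-methyl-1H-pyrrol-3-yl of compound 1, and that gave only a 1.5-fold lower number from compound 2 to compound 3 (0.18 log units; within the scatter). The larger steps both start from compound 1 and remove that group, which compound 4 also lacks, so they offer no reason to expect a large move here.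

The expected change is a 1.3-fold higher number from compound 3 to compound 4 (0.11 log units; within the scatter), a small rise that stays within the scatter. For compound 4 the estimated half-life is 0.13 h, with an expected range of 0.06 h to 0.3 h.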

Compound 4, half-life: 0.167 h
Compound 4: middle estimate off by 1.3-fold (0.11 log units), on the low side; measured number inside the range.
By their numbers in this assay, from the lowest: compounds 3, 2 and 4 (each within the scatter of the next); then compound 1.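

In this assay, rearranging the same five carbons from 1,1-dimethylpropyl to isopentyl on this aromatic carbon, next to the ring nitrogen, gives a 1.7-fold higher number from compound 3 to compound 4 (0.22 log units; within the scatter) and so does not separate the two compounds. The branching of this chain therefore shows no clear effect on half-life here, and the open-chain isopentyl group is likewise not separated from the (cyclopent-1-en-1-yl)methyl group, with a 1.1-fold higher number from compound 2 to compound 4 (0.05 log units; within the scatter) as the printed step between them. Compound 2, compound 3 and compound 4 thus form one cluster, while 1-methyl-1H-pyrrol-3-yl alone stands apart, as a 3.8-fold lower number from compound 1 to compound 4 (0.58 log units; beyond the scatter) confirms for this third group made only of carbon.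

No measured information accounts for the separation of compound 1 from the other three compounds. Going by these compounds, it remains open whether the longer half-life belongs to 1-methyl-1H-pyrrol-3-yl alone or would also appear with another nitrogen-containing ring, such as pyridin-3-yl or 1-methylpyrazol-4-yl, or with a chain ending in an amine or a methoxy group on this aromatic carbon.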